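The source may report more compounds than this note shows. Statements on the series, on what has been measured and on what is new or still open speak of the compounds shown alone.

Going by the values given here, compound 2 `CC(C)=CCC1Cc2c(OC(=O)Nc3cccc(F)c3)cc(=O)n(CCCO)c2CC1(C)C` gives 66.1% in a functional assay on PANC-1 cells (Homo sapiens) for inhibition, read by MTT assay, with a stated time of 24 h, tested at 10 uM (on this read-out higher numbers stand for more inhibition at the one concentration tested (going by the name of the read-out) and lower numbers for less inhibition), the higher of the two numbers measured so far. Among the compounds with values here, compound 1 `CC(C)=CCC1Cc2c(OCCCNC(=O)c3cccs3)cc(=O)n(CCCO)c2CC1(C)C` gives 33.6% in this assay, and the one measured step runs a number 32.5 percentage points higher from compound 1 to compound 2 (beyond the scatter). Compound 3 `CC(C)=CCC1Cc2c(OC(=O)Nc3ccc(Cl)c(Cl)c3)cc(=O)n(CCCO)c2CC1(C)C` differs from compound 2 by 3,4-dichlorophenyl in place of 3-fluorophenyl on an amide-type nitrogen. Within the data shown here, the measured step concerns the group on the aromatic oxygen, not the substituents on the phenyl carried by the amide-type nitrogen, so no measured step bears on this change; the series holds no comparison of one substituted phenyl against another on that nitrogen. No direction can be read from the numbers. The working expectation is therefore a step from compound 2 to compound 3 of a number 0.1 percentage points lower from compound 2 to compound 3 (within the scatter), within the scatter, carrying a broad range. Compound 3 is accordingly estimated at 66% in this assay, with a range from 45% to 85%.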

Compound 3, a percentage reported as inhibition, at one concentration (the size of the read-out at that concentration, not a potency): 61.4%
Beside the measured number, compound 3's estimate is 4.6 percentage points above it; low and high end bracket the measured number.
By their numbers in this assay, from the lowest: compound 1; then compounds 3 and 2 (each within the scatter of the next).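

In this assay, 3,4-dichlorophenyl in place of 3-fluorophenyl on the amide-type nitrogen gives a number 4.7 percentage points lower from compound 2 to compound 3 (within the scatter), so this read-out does not separate these two substituted phenyls at this position. (3,4-Dichlorophenyl)carbamoyl in place of 3-(((thiophen-2-yl)carbonyl)amino)propyl on the aromatic oxygen gives a number 27.8 percentage points higher from compound 1 to compound 3 (beyond the scatter), so the difference from compound 1 is now seen with two carbamoyl groups rather than one. Nothing measured here accounts for either step.

Open, from the compounds shown here alone, is whether a phenyl carrying a methoxy group or a carboxylic acid, or a cyclohexyl group in place of the phenyl, would read differently on that nitrogen. Also open, going by these compounds, is how much of the difference from compound 1 belongs to the carbamoyl link and how much to the phenyl it carries.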